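A few compounds are considered here, and "the series" means these few. Any claim that something is new, unique, unknown or untested is made for them only; others in the source may bear on it.

Working notes on the series. Among the compounds with values here, compound 1 `C=CCc1cc(C(C)=O)c(O)cc1OCCCCC#N` is the reference point: in an assay on isolated protein for binding affinity to leukotriene B4 receptor 1 (Homo sapiens), tested at 1 uM (a lower number here means less inhibition, a higher number more inhibition at the concentration tested (going by the name of the read-out)), compound 1 gives 57%, the highest of the three numbers so far, though neither companion is separated from it beyond the scatter. Compound 2 `C=CCc1cc(C(C)=O)c(O)cc1OCCCCCCCCC#N` gives 50% and compound 3 `C=CCc1cc(C(C)=O)c(O)cc1OCCCCCC(=O)N(C)C` gives 54%. The three measured steps, a number 7 percentage points lower from compound 1 to compound 2 (within the scatter), a number 3 percentage points lower from compound 1 to compound 3 (within the scatter) and a number 4 percentage points higher from compound 2 to compound 3 (within the scatter), all lie within the scatter, so lengthening the chain on the aromatic ether oxygen or exchanging its terminal nitrile for a dimethylcarbamoyl group has left the read-out essentially flat.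

Compound 4 `C=CCc1cc(C(=O)CCCCCCCCC)c(O)cc1OCCCCC#N` takes a different direction. The change from compound 1 is octyl in place of hydrogen on a saturated chain carbon bound to a carbonyl carbon. Within the data shown here, none of the measured steps touches the chain on the carbonyl carbon; all three concern the ether-linked chain, so no measured step bears directly on this change. What the three steps do show is that sizable additions elsewhere on the shared core have moved the number by no more than the scatter. On that basis compound 4 is expected to stay near compound 1, with the step of a number 2 percentage points lower from compound 1 to compound 4 (within the scatter) expected to be small and of no firm direction. The estimate for compound 4 in this assay is 55%, within a range from 35% to 75%, the width reflecting the absence of any precedent for a change at this position.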

Compound 4, a percentage reported as inhibition, at one concentration (the size of the read-out at that concentration, not a potency): 7%
The estimate for compound 4 lay 48 percentage points above the measured number; the whole stated range lies above it.
By their numbers in this assay, from the lowest: compound 4; then compounds 2, 3 and 1 (each within the scatter of the next).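

Within the data shown here, the chain on the carbonyl carbon is the first place where a change stands clear of the scatter: with octyl in place of hydrogen on a saturated chain carbon bound to a carbonyl carbon, this assay shows a number 50 percentage points lower from compound 1 to compound 4 (beyond the scatter) and thus a large loss of inhibition at the concentration tested, while every measured step on the ether-linked chain stayed within the scatter. The read-out therefore does not respond alike at the two ends of the shared core: the longer ether-linked chain of compound 2 leaves the number close to that of compound 1, but the added octyl of compound 4 does not. The compounds shown offer no measurement that explains this drop.

Open, from the compounds shown here alone, is how much of the chain on the carbonyl carbon the read-out accepts, since an ethyl or a butyl group in place of hydrogen at this carbon would show whether the number falls gradually or only with a long chain. Also open, going by these compounds, is whether a carboxylic acid or an amine at the far end of the octyl chain would give a different number from compound 4.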